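The compounds below may be only part of what the source reports. "The series", "measured", "known", "first", "only" and "open" are said of these compounds alone.

Compound 1 `CC1(C)[C@H]2CC[C@]1(C)N(Cc1cn(-c3ccccc3Br)nn1)C(=O)C2` gives 60 nM
Compound 2 `CC1(C)[C@H]2CC[C@]1(C)N(Cc1cn(-c3ccccc3)nn1)C(=O)C2` gives 50 nM
Compound 3 `CC1(C)[C@H]2CC[C@]1(C)N(Cc1cn(-c3cccc(Br)c3)nn1)C(=O)C2` gives 30 nM

All three compounds were tested in a functional assay on LoVo cells (Homo sapiens) for inhibition, read by MTT assay, with a stated time of 24 h (a higher number here means a weaker inhibitor, a lower number a stronger inhibitor), and they sit close together. Compound 3, at 30 nM, lies within the scatter of the other two, with a 2.0-fold lower number from compound 1 to compound 3 (0.30 log units; within the scatter) and a 1.7-fold lower number from compound 2 to compound 3 (0.22 log units; within the scatter) as the steps that reach it. Compound 4 `COc1ccc(-n2cc(CN3C(=O)C[C@@H]4CC[C@@]3(C)C4(C)C)nn2)cc1` now carries 4-methoxyphenyl in place of 3-bromophenyl on an aromatic nitrogen. The other change measured at this group, a 1.2-fold lower number from compound 1 to compound 2 (0.08 log units; within the scatter), was also small. No measured compound carries a methoxy group, so the evidence is indirect, but these steps give no reason to expect a shift beyond the scatter in this assay. The expected change is small (a 1.3-fold higher number from compound 3 to compound 4 (0.12 log units; within the scatter)). For compound 4 the estimated value is 40 nM, with an expected range from 15 nM to 110 nM.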

Compound 4, half-maximal inhibitory concentration: 70 nM
The estimate for compound 4 lay 1.8-fold (0.24 log units) below the measured number; the range from low to high includes it.
By their numbers in this assay, from the lowest: compounds 3, 2, 1 and 4 (each within the scatter of the next, the first and the last beyond it).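

In this assay, this position on the aromatic nitrogen gives its first step beyond the scatter (a 2.3-fold higher number from compound 3 to compound 4 (0.37 log units; beyond the scatter)), so the exchange of 3-bromophenyl for 4-methoxyphenyl is not silent here. That step stands alone, since the other two new steps stay within the scatter (a 1.4-fold higher number from compound 2 to compound 4 (0.15 log units; within the scatter); a 1.2-fold higher number from compound 1 to compound 4 (0.07 log units; within the scatter)), and the methoxy group shows no clear change against the unsubstituted phenyl of compound 2. Nothing available explains the step. The compounds shown leave open how 3-methoxyphenyl would compare with 3-bromophenyl, and how an amine or a carboxylic acid on the phenyl group would read.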